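This account rests on a few compounds, and the source may have more. Where it says the series, first, only, none or still open, it means among the compounds named here.

Among the compounds with values here, in a functional assay on A549 cells (Homo sapiens) for cytotoxicity, read by MTT assay (on this read-out higher numbers stand for weaker inhibition and lower numbers for stronger inhibition), compound 2 `CCOC(=O)C(C)Oc1cc(O)c2c(=O)c(O)c(-c3ccc(OC)cc3)oc2c1CC=C(C)C` gives 26500 nM, the only true number so far. Compound 1 `COc1ccc(-c2oc3c(CC=C(C)C)c(OCCOC(=O)CCC(=O)O)cc(O)c3c(=O)c2OCCOC(=O)CCC(=O)O)cc1` gives > 100000 nM, which is a limit of the assay and not a number. Compound 3 `COc1ccc(-c2oc3c(CC=C(C)C)c(OCCCC(=O)O)cc(O)c3c(=O)c2O)cc1` carries 3-carboxypropyl in place of 1-(ethoxycarbonyl)ethyl on an oxygen on an aromatic ring. Compound 1 also ends in carboxy groups, and its result stands as the limit of > 100000 nM in this assay, at which 1 of the 2 values shown sits, so a move towards weaker inhibition in this assay is expected, with the estimated step of a 1.9-fold higher number from compound 2 to compound 3 (0.28 log units; within the scatter). Compound 3 is estimated at 50000 nM, with an expected range of 20000 nM to 100000 nM.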

Compound 3, half-maximal inhibitory concentration: 19100 nM
Compound 3: middle estimate off by 2.6-fold (0.42 log units), on the high side; measured number below the stated range.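

In this assay, 3-carboxypropyl in place of 1-(ethoxycarbonyl)ethyl on an oxygen on an aromatic ring gives a 1.4-fold lower number from compound 2 to compound 3 (0.14 log units; within the scatter). On this oxygen, then, the two chains cannot be told apart, so a chain ending in a carboxylic acid is tolerated as well as the one it replaces. Compound 1 remains a limit of the assay and not a number: the limit of > 100000 nM in this assay, at which 1 of the 3 values shown sits.

The compounds shown leave open whether an amine at the end of the chain, or a longer chain, on this oxygen would move the number beyond the scatter.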